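This account rests on a few compounds, and the source may have more. Where it says the series, first, only, none or still open, it means among the compounds named here.

Compound 3 `Cc1ccc(S(=O)(=O)Oc2ccccc2/C=C(\C#N)C(=O)Nc2nnc(Cc3ccccc3)s2)cc1` stands lowest of the three measured compounds in an ADME assay on HEK-293T cells (Homo sapiens) for inhibition, read by CCK-8 assay, with a stated time of 48 h, tested at 20 uM (on this read-out higher numbers stand for more inhibition of growth at the one concentration tested and lower numbers for less inhibition of growth), at 15% on this read-out, while compound 1 `COc1ccc(Cc2nnc(NC(=O)/C(C#N)=C/c3ccccc3OS(=O)(=O)c3ccc(OC)cc3)s2)cc1` gives 30% and compound 2 `COc1ccc(S(=O)(=O)Oc2ccccc2/C=C(\C#N)C(=O)Nc2nnc(Cc3cccc4ccccc34)s2)cc1` gives 29% on the same scale. Compound 4 `COc1ccc(S(=O)(=O)Oc2ccccc2/C=C(\C#N)C(=O)Nc2nnc(Cc3ccccc3)s2)cc1` departs from compound 3 in one place: methoxy in place of methyl on an aromatic carbon turning 4-methylphenyl into 4-methoxyphenyl, that is, methoxy in place of methyl on an aromatic carbon. For the measured compounds named here, no measured step isolates this change. Going by the values given here, the only step available, a number 1 percentage points lower from compound 1 to compound 2 (within the scatter) for naphthalen-1-yl in place of 4-methoxyphenyl, concerns a different group and says little here. The sole hint is indirect: compound 1 at 30% and compound 2 at 29% both carry the (4-methoxyphenyl)sulfonyl group, yet each also differs from compound 3 in another group. A small rise in this assay is therefore expected, possibly not beyond the scatter. The estimated step is a number 7 percentage points higher from compound 3 to compound 4 (within the scatter) and it remains uncertain in size. Compound 4 is expected at 22% with an estimated range of 10% to 35% on this read-out.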

Compound 4, percent growth inhibition at one concentration: 23%
For compound 4 the middle estimate is 1 percentage points below the measured one; low and high end bracket the measured number.
By their numbers in this assay, from the lowest: compounds 3, 4, 2 and 1 (each within the scatter of the next, the first and the last beyond it).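

In this assay, for the compounds shown here, a number 8 percentage points higher from compound 3 to compound 4 (within the scatter) is the first direct reading of methoxy in place of methyl on this aromatic carbon, para to a large group, and this exchange of one heavy atom for two, with one hydrogen-bond acceptor added, stays inside the scatter. Compound 4 also links the other compounds by single changes: a number 6 percentage points lower from compound 2 to compound 4 (within the scatter) for phenyl in place of naphthalen-1-yl, and a number 7 percentage points lower from compound 1 to compound 4 (within the scatter) for hydrogen in place of methoxy on an aromatic carbon, so every single change read so far lies within the scatter. Nothing available accounts for these numbers.

Still open, as far as these compounds go, is whether an amine or a carboxylic acid on this same aromatic carbon would give a step beyond the scatter. Also open, from the compounds shown here alone, is how a longer chain in place of the methoxy would read.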